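A few compounds are considered here, and "the series" means these few. Any claim that something is new, unique, unknown or untested is made for them only; others in the source may bear on it.

Measured so far:
- compound 1 `Cc1cc(C)cc(S(=O)(=O)c2c(C(N)=O)[nH]c3ccc(Cl)cc23)c1`: 13000 nM
- compound 2 `Cc1cc(C)cc(S(=O)(=O)c2c(C(=O)NS(C)(=O)=O)[nH]c3ccc(Cl)cc23)c1`: 40200 nM

In an ADME assay on MT4 cells (Homo sapiens) for cytotoxicity, read by MTT assay, with a stated time of 5 days (on this read-out higher numbers stand for lower toxicity in this test and lower numbers for higher toxicity in this test), compound 2 holds the higher of the two numbers, 40200 nM. Compound 3 `Cc1cc(C)cc(S(=O)(=O)c2c(C(=O)NS(=O)(=O)c3ccccc3)[nH]c3ccc(Cl)cc23)c1` is still to be measured and differs from compound 2 as follows: phenyl in place of methyl on a sulfonyl sulfur. In words, this is phenyl in place of methyl on a sulfonyl sulfur.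

Within the data shown here, only one measured step bears on this change: a 3.1-fold higher number from compound 1 to compound 2 (0.49 log units; beyond the scatter), with methylsulfonyl in place of hydrogen on an amide-type nitrogen. That step is modest and beyond the scatter, but it does not test a change on the sulfonyl sulfur, so the direction is uncertain. With compound 2 at the top of the two values, at 40200 nM, a modest move to a lower number in this assay is expected. The estimated step is a 1.6-fold lower number from compound 2 to compound 3 (0.21 log units; within the scatter). For compound 3 the estimate is 25000 nM, with an expected range of 9000 nM to 65000 nM.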

Compound 3, half-maximal cytotoxic concentration: 167000 nM
Compound 3: middle estimate off by 6.7-fold (0.82 log units), on the low side, outside the stated range (above it).
By their numbers in this assay, from the lowest: compound 1; then compound 2; then compound 3.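

Changing the group on the sulfonyl sulfur moves the number in this assay (a 4.2-fold higher number from compound 2 to compound 3 (0.62 log units; beyond the scatter)), so this position is not neutral in this test, and phenyl gives lower toxicity in this test than methyl. Phenylsulfonyl in place of hydrogen on the amide-type nitrogen gives a large step (a 13-fold higher number from compound 1 to compound 3 (1.11 log units; beyond the scatter)), whereas methylsulfonyl gave a modest one (a 3.1-fold higher number from compound 1 to compound 2 (0.49 log units; beyond the scatter)), and none of the three compounds goes against this upward order. Nothing shown here explains the rise.

Methyl and phenyl are the only two groups shown on the sulfonyl sulfur, so it remains open whether a longer chain such as butyl would also raise the number or whether the aromatic ring is needed. Also open, as far as these compounds go, is how an amine such as dimethylamino would behave at the same sulfur.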